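The source may hold more compounds than are shown below. What is called first, only, known or untested is meant among the compounds shown, and "the series" means these compounds.

Measured so far in a functional assay on ileum (Cavia porcellus) for inhibition of cysteinyl leukotriene receptor (Homo sapiens); a higher number here means a more potent compound, by a factor of ten per unit of this negative logarithm, a lower number a less potent compound:
Compound 1 `CCCc1c(OCCCCCCCCC(=O)O)ccc(C(C)=O)c1O` gives 5.8.
Compound 2 `CCCc1c(OCCCCCCc2nn[nH]n2)ccc(C(C)=O)c1O` gives 7.1.
Compound 3 `CCCc1c(OCCCCCCCc2nn[nH]n2)ccc(C(C)=O)c1O` gives 7.

Among these three numbers compound 3 sits second highest in this assay; its nearest neighbour is compound 2, whose value differs from it only within the scatter, and the furthest is compound 1, which lies well below.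

Compound 4 `CCCc1c(OCCCCCc2nn[nH]n2)ccc(C(C)=O)c1O` differs from compound 3 in one place: 2H-tetrazol-5-yl in place of 2-(2H-tetrazol-5-yl)ethyl on a saturated chain carbon, five bonds along the chain from an oxygen on an aromatic ring. The chain that carries the tetrazole is thus made shorter. Within the data shown here, only one measured step concerns chain length alone: a number 0.10 log units lower from compound 2 to compound 3 (within the scatter), where the chain was lengthened and the number did not move beyond the scatter. The other two steps, a number 1.30 log units higher from compound 1 to compound 2 (beyond the scatter) and a number 1.20 log units higher from compound 1 to compound 3 (beyond the scatter), exchange a carboxylic acid for a tetrazole and say less about the change here. Among the measured compounds shown here, the shortening in compound 4 is a larger move than the single step seen, so some drop cannot be excluded, but the data give no ground for a large one. The expected step in this assay is a number 0.20 log units lower from compound 3 to compound 4 (within the scatter), within the scatter. Compound 4 is therefore estimated at 6.8, with a range from 6.2 to 7.3.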

Compound 4, negative logarithm of the antagonist equilibrium constant: 6.6
Beside the measured number, compound 4's estimate is 0.20 log units above it, within the range that was stated.
By their numbers in this assay, from the lowest: compound 1; then compound 4; then compounds 3 and 2 (each within the scatter of the next).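

In this assay, the step of a number 0.40 log units lower from compound 3 to compound 4 (beyond the scatter) and the step of a number 0.50 log units lower from compound 2 to compound 4 (beyond the scatter) show that the chain carrying the 2H-tetrazol-5-yl group cannot be shortened freely, even though compound 2 and compound 3 lie within the scatter of each other. Shortening has a limit here, yet the step of a number 0.80 log units higher from compound 1 to compound 4 (beyond the scatter) shows that compound 4, with its 2H-tetrazol-5-yl group, still stands clear of the carboxylic acid compound 1. Nothing measured here gives a reason for these steps.

The compounds shown leave open whether a still shorter chain would lower the number further, and whether a chain longer than that of compound 3 would hold it. They also leave open how a carboxylic acid would compare on a chain of the same length as that of compound 4.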